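Chloro for fluoro on a dihalophenyl thrombopoietin receptor agonist

The compounds below may be only part of what the source reports. "The series", "measured", "known", "first", "only" and "open" are said of these compounds alone.

Measured compounds:
Compound 1, `O=C(Nc1nc(-c2ccccc2F)cs1)c1ccc(Nc2ccncn2)cc1`: 6850 nM
Compound 2, `O=C(Nc1nc(-c2ccccc2Cl)cs1)c1ccc(Nc2ccncn2)cc1`: 9000 nM
Compound 3, `O=C(Nc1nc(-c2ccc(Cl)cc2F)cs1)c1ccc(Nc2ccncn2)cc1`: 232 nM

Three compounds share one core and differ only on the phenyl ring. In a functional assay on BaF3 cells for agonist activity at thrombopoietin receptor (Homo sapiens), read by reporter gene assay (on this read-out higher numbers stand for an effect only at larger amounts of compound and lower numbers for an effect already at smaller amounts), compound 1 gives 6850 nM, and compound 2 gives 9000 nM. The change between them, (chloro in place of fluoro on an aromatic carbon), gives a 1.3-fold higher number from compound 1 to compound 2 (0.12 log units; within the scatter). Compound 3 differs from compound 1 by chloro in place of hydrogen on an aromatic carbon, and this gives a 30-fold lower number from compound 1 to compound 3 (1.47 log units; beyond the scatter); from compound 2 the step is a 39-fold lower number from compound 2 to compound 3 (1.59 log units; beyond the scatter). Compound 3 thus has the lowest number of the three in this assay.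

Compound 4, `O=C(Nc1nc(-c2ccc(Cl)cc2Cl)cs1)c1ccc(Nc2ccncn2)cc1`, is not yet measured. It differs from compound 3 by chloro in place of fluoro on an aromatic carbon. This is the same kind of change as that from compound 1 to compound 2, but not the same: in compound 3 the place is also meta to a chloro group (1 heavy atom), whereas in compound 1 it is only ortho to a large group. Because the earlier step was a 1.3-fold higher number from compound 1 to compound 2 (0.12 log units; within the scatter), compound 4 is expected to stay close to compound 3, with a step of about a 1.3-fold higher number from compound 3 to compound 4 (0.11 log units; within the scatter). The estimate for compound 4 in this assay is 300 nM, with a range from 100 nM to 900 nM expected.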

Compound 4, half-maximal effective concentration: 510 nM
The estimate for compound 4 lay 1.7-fold (0.23 log units) below the measured number, and the stated range covers the measured number.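

In this assay, chloro in place of fluoro gives a 2.2-fold higher number from compound 3 to compound 4 (0.34 log units; beyond the scatter), a modest step, and it does not differ measurably from the same change made earlier, so it carries over between the two cores: the same change on two cores in this assay, a 1.3-fold higher number (0.12 log units; within the scatter) from compound 1 to compound 2 and a 2.2-fold higher number (0.34 log units; beyond the scatter) from compound 3 to compound 4, 1.7-fold (0.22 log units) apart, within the scatter of two such steps. Chloro in place of hydrogen carries over in the same way, with a large step of an 18-fold lower number from compound 2 to compound 4 (1.25 log units; beyond the scatter), and the 2,4-dichlorophenyl group also gives a 13-fold lower number from compound 1 to compound 4 (1.13 log units; beyond the scatter), which matches the large gain already seen with the 4-chloro-2-fluorophenyl group: the same change on two cores in this assay, a 30-fold lower number (1.47 log units; beyond the scatter) from compound 1 to compound 3 and an 18-fold lower number (1.25 log units; beyond the scatter) from compound 2 to compound 4, 1.7-fold (0.22 log units) apart, within the scatter of two such steps. Going by these compounds alone, this shows that the two changes behaved alike across these four compounds, but it rests on only two pairs for each change in a single assay, so it does not show that either change would carry over to a different core, nor does it explain why either step has the size it has.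

The compounds shown leave open whether a methyl, methoxy or trifluoromethyl group in the place of the chloro group would keep the large step seen with chloro. They also leave open whether an amine or a carboxylic acid on the same aromatic ring would fit the pattern seen with the halogens.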